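The source may report more compounds than this note shows. Statements on the series, on what has been measured and on what is new or still open speak of the compounds shown alone.

For the measured compounds named here, in a physicochemical assay for solubility, read by HPLC, with a stated time of 24 h (a lower number here means a less soluble compound, a higher number a more soluble compound), compound 3 `CC(C)(C)c1[nH]cnc1/C=c1\[nH]c(=O)/c(=C/c2cccc(C(=O)N3CCC3)c2)[nH]c1=O` gives 4.23 ug/mL, the only actual number so far. Compound 1 `CC(C)(C)c1[nH]cnc1/C=c1\[nH]c(=O)/c(=C/c2cccc(C(=O)c3ccccc3)c2)[nH]c1=O` reads < 0.1 ug/mL, which is a limit of the assay. Compound 2 `O=C(c1ccccc1)c1cccc(/C=c2\[nH]c(=O)/c(=C/c3ccccn3)[nH]c2=O)c1` reads < 0.1 ug/mL, also a limit. Compound 4 `O=C(c1cccc(/C=c2\[nH]c(=O)/c(=C/c3ccccn3)[nH]c2=O)c1)N1CCC1` differs from compound 3 in one place: pyridin-2-yl in place of 5-(tert-butyl)-1H-imidazol-4-yl on a double-bonded chain carbon bound to an aromatic carbon. The same swap appears as a step that the two limits leave unreadable from compound 1 to compound 2, so it offers no size to carry over. The other measured step, an at least 42-fold higher number from compound 1 to compound 3 (1.62 log units; beyond the scatter), is large, but it is a different swap, on a carbonyl carbon. With no measured size for this swap, no change beyond the scatter is expected in this assay, although the uncertainty is wide. The expected step is a 1.4-fold lower number from compound 3 to compound 4 (0.15 log units; within the scatter). For compound 4 the estimated value is 3 ug/mL, with an expected range of 0.5 ug/mL to 15 ug/mL.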

Compound 4, solubility: 0.662 ug/mL
Compound 4: the middle estimate sits 4.5-fold (0.66 log units) above what was measured; the measured number falls inside the stated range.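

In this assay the change to pyridin-2-yl from 5-(tert-butyl)-1H-imidazol-4-yl now has a readable size, a 6.4-fold lower number from compound 3 to compound 4 (0.81 log units; beyond the scatter) and beyond the scatter. Azetidin-1-yl in place of phenyl on a carbonyl carbon also gives an at least 6.6-fold higher number from compound 2 to compound 4 (0.82 log units; beyond the scatter) with pyridin-2-yl present, so that swap raises the number with either group on the chain carbon. This size is only a floor, since compound 2 stands at a limit: the limit of < 0.1 ug/mL in this assay, at which 2 of the 4 values shown sit.

Whether the tert-butyl or the ring accounts for the fall stays open, as a plain 1H-imidazol-4-yl would be needed to separate them. As far as these compounds go, how an amine or a carboxylic acid would read on that chain carbon is also open.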